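A few compounds are considered here, and "the series" means these few. Any claim that something is new, unique, unknown or untested is made for them only; others in the source may bear on it.

In a functional assay on HeLa cells (Homo sapiens) for inhibition, read by sulforhodamine B assay (on this read-out higher numbers stand for weaker inhibition and lower numbers for stronger inhibition), the measured compounds stand as follows:

compound 1 `O=C1C=C(Nc2ccc(I)cc2)C(=O)c2c1nc1n2[C@H]2OC[C@@H](O)[C@H]2OC1`: 4070 nM
compound 2 `CCCc1ccc(NC2=CC(=O)c3c(nc4n3[C@H]3OC[C@@H](O)[C@H]3OC4)C2=O)cc1`: 6030 nM
compound 3 `COc1cccc(NC2=CC(=O)c3nc4n(c3C2=O)[C@H]2OC[C@@H](O)[C@H]2OC4)c1`: 4280 nM

Compound 2 gives the highest of the three numbers, yet its gaps to compound 3 and to compound 1 are both within the scatter, so no order among the three is read from these values. Compound 4 `O=C1C(Nc2ccc(C(F)(F)F)cc2)=CC(=O)c2c1nc1n2[C@H]2OC[C@@H](O)[C@H]2OC1` differs from compound 2 by trifluoromethyl in place of propyl on an aromatic carbon. For the measured compounds named here, the one measured step, a 1.1-fold higher number from compound 1 to compound 3 (0.02 log units; within the scatter), also exchanges the aryl group on the amine nitrogen and stays within the scatter; no measured step exchanges propyl for trifluoromethyl, and the three aryl variants together span a range that is within the scatter. A step of a 1.2-fold lower number from compound 2 to compound 4 (0.08 log units; within the scatter) is therefore expected, not beyond the scatter. Compound 4 is estimated at 5000 nM, with a range from 2500 nM to 10000 nM.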

Compound 4, half-maximal inhibitory concentration: 8920 nM
Estimate against measurement, compound 4: 1.8-fold (0.25 log units) below; measured number inside the range.
By their numbers in this assay, from the lowest: compounds 1, 3, 2 and 4 (each within the scatter of the next, the first and the last beyond it).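

In this assay, the exchange of propyl for trifluoromethyl on this aromatic carbon gives a 1.5-fold higher number from compound 2 to compound 4 (0.17 log units; within the scatter). For the compounds shown here, this is the first reading of that exchange: at this place, para to a large group, the two groups cannot be told apart, although they differ in atoms and in heavy-atom count. No measurement on hand bears on this result.

Still open, going by these compounds, is whether a carboxylic acid, an amine or a chain longer than propyl on this carbon would give a step beyond the scatter.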